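The source may hold more compounds than are shown below. What is called first, only, known or untested is meant among the compounds shown, and "the series" means these compounds.

Among the compounds with values here, in a functional assay on SK-OV-3 cells (Homo sapiens) for antiproliferative activity, read by sulforhodamine B assay, with a stated time of 48 h (on this read-out higher numbers stand for weaker inhibition and lower numbers for stronger inhibition), three compounds sharing one core have numbers so far: compound 1 (`O=C1NCCN1c1ccc(S(=O)(=O)Nc2ccc3[nH]ccc3c2)cc1`) gives 280 nM, compound 2 (`COc1cc(NS(=O)(=O)c2ccc(N3CCNC3=O)cc2)cc(OC)c1OC`) gives 22 nM, and compound 3 (`O=C1NCCN1c1ccc(S(=O)(=O)Nc2cccc(Br)c2)cc1`) gives 170 nM. Compound 3 stands close to compound 1, within the usual scatter, and well above compound 2, whose lower number means stronger inhibition. Compound 4 (`Cc1ccc(C)c(NS(=O)(=O)c2ccc(N3CCNC3=O)cc2)c1`), still unmeasured, carries 2,5-dimethylphenyl in place of 3-bromophenyl on a sulfonamide nitrogen. Within the data shown here, no measured pair isolates a single change of this kind, so the data offer only a weak guide. No shift beyond the scatter is expected, and the estimated change is a 1.1-fold lower number from compound 3 to compound 4 (0.05 log units; within the scatter). For compound 4 the estimated value is 150 nM, with a range of 50 nM to 500 nM.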

Compound 4, half-maximal inhibitory concentration: 72 nM
Compound 4: the middle estimate sits 2.1-fold (0.32 log units) above what was measured; the range from low to high includes it.
By their numbers in this assay, from the lowest: compound 2; then compound 4; then compounds 3 and 1 (each within the scatter of the next).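

In this assay, putting 2,5-dimethylphenyl in place of 3-bromophenyl on a sulfonamide nitrogen gives a 2.4-fold lower number from compound 3 to compound 4 (0.37 log units; beyond the scatter), a modest step. Within the data shown here, this is the first single change read, and it shows that the number responds to the aromatic group at this position even when the replacement keeps a six-membered carbon ring. Nothing measured here explains the shift. Going by these compounds, it remains open whether one methyl group alone would give the same step, or how an amine or a carboxylic acid on this ring would read.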